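Replacing an ethyl on the amide nitrogen with a larger group

The source may hold more compounds than are shown below. What is called first, only, known or untested is meant among the compounds shown, and "the series" means these compounds.

Of the compounds shown here, two that share a core have been measured so far. Compound 1 `CCNC(=O)c1oc2nc(-c3ccccc3)cc(C(F)(F)F)c2c1N` was tested in an ADME assay on HEK293 cells (Homo sapiens) for antiproliferative activity, read by MTT assay (a higher number here means a weaker inhibitor, a lower number a stronger inhibitor), where compound 1 gives 70000 nM. Compound 2 `CNC(=O)c1oc2nc(-c3cccs3)cc(C(F)(F)F)c2c1N` carries a different ring on the core and a methyl instead of an ethyl on the amide nitrogen; in this assay compound 2 gives 75000 nM. The two numbers sit within the usual scatter of each other, so neither can be called stronger or weaker than the other.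

The next compound is compound 3 `Nc1c(C(=O)N/N=C/c2ccc(Cl)cc2)oc2nc(-c3ccccc3)cc(C(F)(F)F)c12`, which differs from compound 1 in one place: a group of 9 heavy atoms (7 carbon, 1 nitrogen, 1 chlorine; one six-membered aromatic ring of carbon only) in place of a group of 2 heavy atoms (2 carbon; no ring), on an amide-type nitrogen. The entering group is much larger than the ethyl it replaces and brings an aromatic ring and a double bond of its own.

Within the data shown here, no measured pair shows what such a change does in this assay, so any expectation rests on the structural change alone. The step from compound 1 to compound 3 is expected to be modest, toward a lower number, about a 1.8-fold lower number from compound 1 to compound 3 (0.24 log units; within the scatter). For compound 3 the expected value is 40000 nM, with a range from 10000 nM to 120000 nM.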

Compound 3, half-maximal inhibitory concentration: 81000 nM
Beside the measured number, compound 3's estimate is 2.0-fold (0.31 log units) below it, and the stated range covers the measured number.
By their numbers in this assay, from the lowest: compounds 1, 2 and 3 (each within the scatter of the next).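

In this assay, putting the much larger group in place of the ethyl on the amide-type nitrogen gives a 1.2-fold higher number from compound 1 to compound 3 (0.06 log units; within the scatter). Among these compounds, this is the first comparison in which only this one place differs. Compounds 1 and 2 differ in both the ring on the core and the group on the nitrogen. The comparison shows that the numbers for compound 1 and compound 3 cannot be told apart even though the entering group brings a six-membered aromatic ring, a chlorine and a double bond outside aromatic rings. No measurement at hand offers an explanation for this result.

Going by these compounds, a single large group says little about this position as a whole, so it remains open whether the same group without its chlorine, a longer alkyl chain, an amine or a carboxylic acid on this nitrogen would give a number beyond the scatter. On these data alone, it also remains open whether the same exchange would give a similar result on compound 2, with its different ring on the core.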